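This account rests on a few compounds, and the source may have more. Where it says the series, first, only, none or still open, it means among the compounds named here.

Compound 1 `CC(C)(C)OC(=O)N1CCC(O[C@H]2CC[C@H](Oc3cnc(S(C)(=O)=O)cn3)CC2)CC1`: 94 nM
Compound 2 `CC(C)OC(=O)N1CCC(O[C@H]2CC[C@H](Oc3cnc(S(C)(=O)=O)cn3)CC2)CC1`: 92.7 nM

In an assay on isolated protein for agonist activity at Glucose-dependent insulinotropic receptor (Homo sapiens) (on this read-out higher numbers stand for an effect only at larger amounts of compound and lower numbers for an effect already at smaller amounts), compound 2 gives the lower of the two numbers, but its gap to compound 1 is small: a 1.0-fold lower number from compound 1 to compound 2 (0.01 log units; within the scatter). So on the numbers shown the two compounds cannot be told apart.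

Compound 3 `CC(C)c1noc(CN2CCC(O[C@H]3CC[C@H](Oc4cnc(S(C)(=O)=O)cn4)CC3)CC2)n1` has not been measured yet. It differs from compound 2 in one place: (3-isopropyl-1,2,4-oxadiazol-5-yl)methyl in place of isopropoxycarbonyl on an amine nitrogen in a ring. Among the compounds with values here, this is a different kind of change from the only measured step. That step, from compound 1 to compound 2, only shortened the chain on the group that now leaves entirely, and it changed nothing beyond the scatter. Within the data shown here, it therefore says little about what happens when the whole isopropoxycarbonyl is exchanged for a ring-bearing group, and no measured pair shows such an exchange.

Among the measured compounds shown here, with no direct precedent, the most reasonable expectation for compound 3 is a number near that of compound 2, so the expected step of a 1.1-fold higher number from compound 2 to compound 3 (0.03 log units; within the scatter) is close to none, with wide uncertainty in both directions. The estimate for compound 3 in this assay is 100 nM, in a range from 25 nM to 400 nM.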

Compound 3, half-maximal effective concentration: 64.9 nM
Estimate against measurement, compound 3: 1.5-fold (0.19 log units) above; the range from low to high includes it.
By their numbers in this assay, from the lowest: compounds 3, 2 and 1 (each within the scatter of the next).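

The earlier step only trimmed the chain on the carbonyl-bearing group, whereas this exchange replaces that whole group on the amine nitrogen in a ring. In this assay the exchange gives a 1.4-fold lower number from compound 2 to compound 3 (0.15 log units; within the scatter) and, against the larger tert-butoxycarbonyl group, a 1.4-fold lower number from compound 1 to compound 3 (0.16 log units; within the scatter) as well. This position therefore accepts (3-isopropyl-1,2,4-oxadiazol-5-yl)methyl, which brings a five-membered aromatic ring with 3 hetero atoms and has no double bond outside aromatic rings, without a change that can be told from the scatter. So, for these three compounds, the isopropoxycarbonyl and tert-butoxycarbonyl groups are not needed on this nitrogen for a number of this size, although nothing shown here gives a reason for that result.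

The compounds shown leave open how little this nitrogen can carry, since a bare amine with only a hydrogen there, or a simple methyl group, would test whether any group is needed at all. They also leave open whether the isopropyl on the oxadiazole matters, which a compound with a tert-butyl or a cyclopropyl group in its place could show.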